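A few compounds are considered here, and "the series" means these few. Any claim that something is new, unique, unknown or untested is made for them only; others in the source may bear on it.

Compound 1 `CC(C)(C(=O)O)c1nn(Cc2cn3cc(OCC4CC4)c(Cl)cc3n2)c2ccccc2c1=O` has the lowest number of the two measured in a functional assay on CHO cells for antagonist activity at sphingosine 1-phosphate receptor 2 (Homo sapiens), read by calcium flux; a higher number here means a weaker inhibitor, a lower number a stronger inhibitor: in that assay compound 1 gives 7.7 nM. Compound 2 `O=C(Cc1nn(CC(=O)N2CCOCC2)c(=O)c2ccccc12)Nc1ccc(OC(F)(F)F)c(Cl)c1`, built on the same core but with a different set of side groups, gives 30 nM in this assay, a gap from compound 1 that lies beyond the usual scatter. Compound 3 `COc1ccc(Cl)cc1NC(=O)Cc1nn(CC(=O)O)c(=O)c2ccccc12` gives only a limit of the assay, > 1790 nM, in this assay; (the limit of > 1790 nM in this assay, at which 1 of the 3 values shown sits). Compound 4 `CC(C(=O)O)c1nn(Cc2cn3cc(OCC4CC4)c(Cl)cc3n2)c2ccccc2c1=O` has not yet been measured. It differs from compound 1 in a single place: hydrogen in place of methyl on a saturated chain carbon bound to an aromatic carbon, a carbonyl carbon and a saturated chain carbon. Within the data shown here, no pair of measured compounds here differs in exactly one place, so there is no measured step of this kind to draw on. Since only one carbon is removed and the carboxylic acid stays, the step from compound 1 to compound 4 in this assay is expected to be a 2.6-fold higher number from compound 1 to compound 4 (0.41 log units; beyond the scatter), a mild loss that may not exceed the scatter. Compound 4 is therefore estimated at 20 nM, with a range from 5 nM to 80 nM.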

Compound 4, half-maximal inhibitory concentration: 6 nM
The estimate for compound 4 lay 3.3-fold (0.52 log units) above the measured number, and the stated range covers the measured number.
By their numbers in this assay, from the lowest: compounds 4 and 1 (each within the scatter of the next); then compound 2. At a limit, above all of these: compound 3.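

In this assay, among these compounds, the change from 1-carboxy-1-methylethyl to 1-carboxyethyl gives a 1.3-fold lower number from compound 1 to compound 4 (0.11 log units; within the scatter) and is the first single-place step available in this set. At this saturated chain carbon, removing one methyl and leaving hydrogen therefore produces no difference that can be told from the scatter, so the second methyl of compound 1 is not required for the number seen in this assay. No measurement shown bears on why the two compounds match.

The compounds shown leave open whether the remaining methyl of compound 4 could also give way to hydrogen, or be replaced by a larger group such as an ethyl or a longer chain. They also leave open how an amide or an ester would fare in place of the carboxylic acid at this same carbon.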